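This account rests on a few compounds, and the source may have more. Where it says the series, first, only, none or still open, it means among the compounds named here.

Measured in an ADME assay for protein binding, using equilibrium dialysis, at pH 7.4, tested at 2 uM; a higher number here means a larger unbound share of the compound, a lower number a smaller unbound share:
- Compound 1 `CC(C)N(c1cc(C#CC(C)(C)C)sc1C(=O)O)C(=O)[C@H]1CC[C@H](C)CC1`: 0.06
- Compound 2 `CC(C)N(C(=O)C1CCCCC1)c1cc(C#CC(C)(C)C)sc1C(=O)O`: 0.18
- Compound 3 `CC(C)N(c1cc(C#CC(C)(C)C)sc1C(=O)O)C(=O)[C@H]1CC[C@H](Cl)CC1`: 0.14

In this assay, compound 1 stands lowest of the three, with 0.06. Compound 4 `C[C@@H](CCOc1cccnc1)N(c1cc(C#CC(C)(C)C)sc1C(=O)O)C(=O)[C@H]1CC[C@H](C)CC1` keeps the rest of compound 1 but turns its isopropyl into 1-methyl-3-((pyridin-3-yl)oxy)propyl: ((pyridin-3-yl)oxy)methyl in place of hydrogen on a saturated chain carbon, two bonds along the chain from an amide-type nitrogen. For the measured compounds named here, no measured step touches this place, so the available steps, all made on a saturated ring carbon, offer only a loose guide. Swapping the ring methyl for hydrogen gives a 3.0-fold higher number from compound 1 to compound 2 (0.48 log units; beyond the scatter), and swapping it for chloro gives a 2.3-fold higher number from compound 1 to compound 3 (0.37 log units; beyond the scatter). Losing atoms at that ring carbon thus raised the number once, which hints that adding atoms could lower it. Compound 3 goes against so simple a link, since the chloro group gives a 1.3-fold lower number from compound 2 to compound 3 (0.11 log units; within the scatter). No step beyond the scatter is therefore expected, and the estimate is a 1.2-fold lower number from compound 1 to compound 4 (0.08 log units; within the scatter). The estimated value for compound 4 is 0.05, with an expected range of 0.02 to 0.12.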

Compound 4, unbound fraction: 0.02
For compound 4 the middle estimate is 2.5-fold (0.40 log units) above the measured one; the range from low to high includes it.
By their numbers in this assay, from the lowest: compound 4; then compound 1; then compounds 3 and 2 (each within the scatter of the next).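

Until now, every step in this assay sat on a saturated ring carbon, so the isopropyl group had not been tested. Turning it into 1-methyl-3-((pyridin-3-yl)oxy)propyl gives a 3.0-fold lower number from compound 1 to compound 4 (0.48 log units; beyond the scatter) and so shows that this position also affects the unbound share, with a change beyond the scatter toward a smaller share. Nothing measured here explains this fall.

The compounds shown leave open which part of the new group matters: the pyridine ring, the ether oxygen or the longer chain alone, which a plain phenyl ether or a simple alkyl chain of the same length could help separate. Also open, as far as these compounds go, is whether an amine or a carboxylic acid at the end of this chain would move the number the other way.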